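Dienyl chain to 4-chlorophenyl on the butenolide series

A few compounds are considered here, and "the series" means these few. Any claim that something is new, unique, unknown or untested is made for them only; others in the source may bear on it.

Compound 3 `C=C1CC[C@@H]2[C@](C)(COC(=O)c3cccnc3)[C@H](OC(=O)c3cccnc3)CC[C@@]2(C)[C@@H]1/C=C/C1=C/C(=C\C(C)=C\CCC/C=C/C)OC1=O` gives 28000 nM in an assay on isolated protein for inhibition of Maltase-glucoamylase (Homo sapiens) (on this read-out higher numbers stand for weaker inhibition and lower numbers for stronger inhibition), and stands with the lowest number of the three measured compounds; compound 1 `C=C1CC[C@@H]2[C@](C)(CO)[C@H](O)CC[C@@]2(C)[C@@H]1/C=C/C1=C/C(=C/c2ccccc2)OC1=O` gives 58000 nM and compound 2 `C=C1CC[C@@H]2[C@](C)(CO)[C@H](O)CC[C@@]2(C)[C@@H]1/C=C/C1=C/C(=C/c2ccc(N(C)C)cc2)OC1=O` gives 70000 nM in this assay, both beyond the scatter from compound 3. Compound 4 `C=C1CC[C@@H]2[C@](C)(COC(=O)c3cccnc3)[C@H](OC(=O)c3cccnc3)CC[C@@]2(C)[C@@H]1/C=C/C1=C/C(=C\c2ccc(Cl)cc2)OC1=O` differs from compound 3 by a group of 7 heavy atoms (6 carbon, 1 chlorine; one six-membered aromatic ring of carbon only) in place of a group of 9 heavy atoms (9 carbon; no ring), on a double-bonded chain carbon bound to a double-bonded ring carbon. Within the data shown here, the only measured step, a 1.2-fold higher number from compound 1 to compound 2 (0.08 log units; within the scatter), varies a substituent on an aryl group already present and does not touch a chain-to-ring exchange, so no measured step bears directly on the change here. The aryl-bearing compounds 1 and 2 carry free hydroxyls where compound 3 carries two nicotinate esters, so their gap to compound 3 mixes two changes and cannot be read as the effect of the chain alone. The expectation for compound 4 is therefore a small shift, a 1.4-fold higher number from compound 3 to compound 4 (0.15 log units; within the scatter), toward the numbers of compounds 1 and 2, not clearly beyond the scatter. Compound 4 is estimated at 40000 nM in this assay, within a range from 15000 nM to 110000 nM.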

Compound 4, half-maximal inhibitory concentration: 6000 nM
For compound 4 the middle estimate is 6.7-fold (0.82 log units) above the measured one, and the stated range ends above it.
By their numbers in this assay, from the lowest: compound 4; then compound 3; then compounds 1 and 2 (each within the scatter of the next).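

In this assay, 4-chlorophenyl in place of the open chain of 9 carbons, on a double-bonded chain carbon bound to a double-bonded ring carbon, gives a 4.7-fold lower number from compound 3 to compound 4 (0.67 log units; beyond the scatter), read with both nicotinate esters held constant. Among these compounds, this shows that the group at this carbon can move the read-out beyond the scatter, which the only earlier step, a 1.2-fold higher number from compound 1 to compound 2 (0.08 log units; within the scatter), did not show, as that step stayed within the scatter and varied a substituent on an aryl group with free hydroxyls. Nothing at hand explains the size or direction of the new step.

The step exchanges the whole group at once, so the compounds shown do not separate the contribution of the aromatic ring from that of the chlorine; a plain phenyl, a 4-bromophenyl or a pyridine ring on the same nicotinate ester scaffold would address this. Also open, going by these compounds, is whether the two nicotinate esters contribute to the lower number of compound 4, which a 4-chlorophenyl analogue carrying the two free hydroxyls or acetate esters in their place would test.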